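The compounds below may be only part of what the source reports. "The series", "measured", "known", "first", "only" and "open" are said of these compounds alone.

In an ADME assay on L6 cells (Rattus norvegicus) for cytotoxicity, read by resazurin assay, with a stated time of 72 h (on this read-out lower numbers stand for stronger inhibition and higher numbers for weaker inhibition), the series reads so far:
- compound 1 `CN(C)C12CC(c3ccccc3)C(CN(C(=O)CN3CCCC3)C1)C(c1ccccc1)C2` gives 12600 nM
- compound 2 `CN(C)C12CC(c3ccccc3)C(CN(C(=O)CCN3CCCCC3)C1)C(c1ccccc1)C2` gives 12400 nM
- compound 3 `CN(C)C12CC(c3ccccc3)C(CN(CCN3CCCC3)C1)C(c1ccccc1)C2` gives 5580 nM

Compound 3 holds the lowest of the three numbers, and both a 2.3-fold lower number from compound 1 to compound 3 (0.35 log units; beyond the scatter) and a 2.2-fold lower number from compound 2 to compound 3 (0.35 log units; beyond the scatter) are modest steps. Next is compound 4 `CCN(CC)CCCN1CC2C(c3ccccc3)CC(N(C)C)(CC2c2ccccc2)C1`, reached through (diethylamino)methyl in place of pyrrolidin-1-yl on a saturated chain carbon, two bonds along the chain from an amine nitrogen in a ring on a saturated chain carbon, two bonds along the chain from an amine nitrogen in a ring. Going by the values given here, the only measured change at the amine end, a 1.0-fold lower number from compound 1 to compound 2 (0.01 log units; within the scatter), stayed within the scatter, though it sits on the carbonyl-linked chains. Among the compounds with values here, no measured step makes this exact exchange. Expected in this assay is a 1.1-fold lower number from compound 3 to compound 4 (0.05 log units; within the scatter) and so no step beyond the scatter. For compound 4 the estimate is 5000 nM, with 2300 nM to 11000 nM as the expected range.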

Compound 4, half-maximal inhibitory concentration: 3270 nM
Beside the measured number, compound 4's estimate is 1.5-fold (0.18 log units) above it; low and high end bracket the measured number.
By their numbers in this assay, from the lowest: compounds 4 and 3 (each within the scatter of the next); then compounds 2 and 1 (each within the scatter of the next).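

In this assay, (diethylamino)methyl, which has no ring, in place of pyrrolidin-1-yl on a saturated chain carbon gives a 1.7-fold lower number from compound 3 to compound 4 (0.23 log units; within the scatter), so this exchange of the amine end does not separate the two compounds. Against the carbonyl-linked chains, 3-(diethylamino)propyl on the amine nitrogen in a ring gives a 3.8-fold lower number from compound 2 to compound 4 (0.58 log units; beyond the scatter) and a 3.9-fold lower number from compound 1 to compound 4 (0.59 log units; beyond the scatter), both modest steps. No supporting data bear on the reason for these results.

Open, as far as these compounds go, is whether a morpholine at the amine end, or a longer chain, would stay within the scatter of compound 4.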